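The source may hold more compounds than are shown below. What is called first, only, known or untested is meant among the compounds shown, and "the series" means these compounds.

Working notes on the series, read in an ADME assay on MT4 cells (Homo sapiens) for cytotoxicity, read by MTT assay; on this read-out lower numbers stand for higher toxicity in this test and higher numbers for lower toxicity in this test. Compound 1 (`Cc1cc(C)cc(CSc2nc(Cc3c(F)cccc3F)c(C)c(=O)[nH]2)c1`) gives > 65000 nM, which is a limit of the assay. Compound 2 (`Cc1c(Cc2c(F)cccc2F)nc(SCc2cccnc2)[nH]c1=O`) gives > 70000 nM, also a limit. Compound 3 (`Cc1c(Cc2c(F)cccc2F)nc(SCc2ccncc2)[nH]c1=O`) gives > 70000 nM, again a limit and not a number. Within the data shown here, no compound has yet given a number in this assay.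

The next change leads to compound 4 (`Cc1c(Cc2c(F)cccc2F)nc(SCC(=O)c2ccc(F)cc2)[nH]c1=O`): (4-fluorophenyl)carbonyl in place of pyridin-4-yl on a saturated chain carbon bound to a sulfur. In words, this is (4-fluorophenyl)carbonyl in place of pyridin-4-yl on a saturated chain carbon bound to a sulfur.

Three measured steps fall at this same place: a step that the two limits leave unreadable from compound 1 to compound 2, a step that the two limits leave unreadable from compound 1 to compound 3 and a step that the two limits leave unreadable from compound 2 to compound 3. None of them has a readable size, so they supply neither a size nor a direction for the new group. The expected change is therefore no step beyond the scatter, and the estimate for it is an at least 1.0-fold lower number from compound 3 to compound 4 (0.03 log units; that floor lies within the scatter). The estimated value for compound 4 is 65000 nM, with an expected range from 25000 nM to 100000 nM.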

Compound 4, half-maximal cytotoxic concentration: > 62000 nM
Compound 4: a limit, no number; the forecaster's own chance of this, stated with the estimate: 65%; the middle value is on the limit's open side.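

In this assay compound 4 gives > 62000 nM, a limit and not a number. The steps from compound 1, compound 2 and compound 3 to compound 4 cannot be read: all four values are limits. Still open, going by these compounds, is how the groups on a saturated chain carbon bound to a sulfur compare on this read-out.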